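Methoxy in place of cyano on a shared core

A few compounds are considered here, and "the series" means these few. Any claim that something is new, unique, unknown or untested is made for them only; others in the source may bear on it.

Compound 1 `CS(=O)(=O)c1cccc(C(=O)N2CCCC(C(=O)Nc3ccc(Cl)cc3)C2)c1` and compound 2 `N#Cc1cccc(C(=O)N2CCCC(C(=O)Nc3ccc(Cl)cc3)C2)c1` share a core and differ only in one group on an aromatic carbon. In an ADME assay on PC-3 cells (Homo sapiens) for cytotoxicity, read by WST assay, tested at 100 uM (on this read-out lower numbers stand for less inhibition and higher numbers for more inhibition at the one concentration tested (going by the name of the read-out)), compound 1 gives 2%, and in the same test compound 2 gives 0%. The step of a number 2 percentage points lower from compound 1 to compound 2 (within the scatter) shows that exchanging methylsulfonyl for cyano at that position leaves the read-out where it was; both compounds sit near the bottom of the scale, within the scatter of each other.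

Compound 3 `COc1cccc(C(=O)N2CCCC(C(=O)Nc3ccc(Cl)cc3)C2)c1` is the next variation at that same position: methoxy in place of cyano on an aromatic carbon. Among the compounds with values here, only one measured step bears on this change, the one from compound 1 to compound 2, and it stayed within the scatter. Nothing in the two measured compounds points to a group at this position shifting the read-out, so the expectation is for compound 3 is a step of a number 2 percentage points higher from compound 2 to compound 3 (within the scatter) that stays within the scatter. The estimated value for compound 3 in this assay is 2%, with a range from -5% to 12%.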

Compound 3, a percentage reported as inhibition, at one concentration (the size of the read-out at that concentration, not a potency): 0%
The estimate for compound 3 lay 2 percentage points above the measured number; low and high end bracket the measured number.
By their numbers in this assay, from the lowest: compounds 2, 3 and 1 (each within the scatter of the next).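

In this assay, methoxy in place of cyano gives no change at the digits printed from compound 2 to compound 3 (within the scatter), and methoxy in place of methylsulfonyl gives a number 2 percentage points lower from compound 1 to compound 3 (within the scatter). With compound 3, the same place on the aromatic ring now carries a third group, one with an oxygen and no triple bond, and the values of all three compounds lie within the scatter of each other, so among these three groups the choice does not move this read-out. No further measurement is available to say why the read-out stays flat across these groups.

The compounds shown leave open whether a group of another kind at this place, such as an amine, a carboxylic acid or a longer chain like butoxy, would give a number clearly apart from these three. They also leave open whether a change elsewhere on the shared core, such as another atom in place of the chlorine, would shift the read-out at the one concentration tested.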